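A few compounds are considered here, and "the series" means these few. Any claim that something is new, unique, unknown or untested is made for them only; others in the source may bear on it.

Measured so far:
Compound 1 `CCc1cc2ccccc2nc1-c1cc(-c2ccc(F)cc2)no1`: in a functional assay on A549 cells (Homo sapiens) for inhibition, read by MTT assay, with a stated time of 24 h (on this read-out lower numbers stand for stronger inhibition and higher numbers for weaker inhibition), compound 1 reaches only the limit > 100000 nM.
Compound 2 `CCc1cc2ccccc2nc1-c1cc(-c2ccc(C)cc2)no1`: in this assay compound 2 likewise reaches only the limit > 100000 nM.

Compound 2 thus stands at a limit, not at a number, and so does compound 1. Among the compounds with values here, the single step between measured compounds, a step that the two limits leave unreadable from compound 1 to compound 2, cannot be read in size or direction because both values sit at the limit of > 100000 nM in this assay, at which 2 of the 2 values shown sit. Compound 3 `CCCCCc1cc2ccccc2nc1-c1cc(-c2ccc(C)cc2)no1` differs from compound 2 by propyl in place of hydrogen on a saturated chain carbon, two bonds along the chain from an aromatic carbon; read one bond further out, the ethyl chain on the shared core becomes a pentyl chain. No measured step concerns a change of this kind, and the only step shown is unreadable, so nothing in the numbers points to a direction or a size for this move in this assay. With compound 2 at a limit, the most likely outcome for compound 3 is that it, too, is reported as a limit rather than as a number. The estimate for compound 3 is 150000 nM, with a range from 20000 nM to 1000000 nM. The step that the limit leaves unreadable from compound 2 to compound 3 is expected to remain within scatter if a number appears at all.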

Compound 3, half-maximal inhibitory concentration: > 100000 nM
Compound 3 gave a limit, no number; the forecaster's own chance of this, stated with the estimate: 80%; the middle value does not contradict the limit.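

No new step can be read from compound 2 to compound 3, because both compounds, like compound 1, stand at a limit and not at a number: the limit of > 100000 nM in this assay, at which 3 of the 3 values shown sit.

The compounds shown leave open whether going from ethyl to pentyl on the shared core changes inhibition at all, and what number any of the three would reach.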